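Working notes: from compound 3 to compound 4

A few compounds are considered here, and "the series" means these few. Any claim that something is new, unique, unknown or untested is made for them only; others in the source may bear on it.

Measured so far, all in (a toxicity assay on CCRF-CEM cells (Homo sapiens) for cytotoxicity; a lower number here means that less compound is tolerated, a higher number that more compound is tolerated)
- compound 1 `Cc1cccc2c1nc(-c1c(F)cccc1F)n2Cc1c(F)cccc1F` gives > 100 uM as a limit of the assay
- compound 2 `COc1cccc2c1nc(-c1c(F)cccc1F)n2Cc1c(F)cccc1F` gives 44.3 uM as a number
- compound 3 `Fc1cccc(F)c1Cn1c(-c2c(F)cccc2F)nc2c(Br)cccc21` gives 24.5 uM as a number

Among the compounds with values here, compound 3 stands level with compound 2 (a 1.8-fold lower number from compound 2 to compound 3 (0.26 log units; within the scatter)), and these two hold the only exact numbers. Compound 4 `CC(=O)N(C)c1cccc2c1nc(-c1c(F)cccc1F)n2Cc1c(F)cccc1F` carries acetyl(methyl)amino in place of bromo on an aromatic carbon.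

Three measured steps exchange a single group on an aromatic carbon: an at least 2.2-fold lower number from compound 1 to compound 2 (0.35 log units; beyond the scatter), an at least 4.0-fold lower number from compound 1 to compound 3 (0.61 log units; beyond the scatter) and the level step above. The two steps from compound 1 rest on the limit of > 100 uM in this assay, at which 1 of the 3 values shown sits, and so fix only a minimum size. None of the three brings in acetyl(methyl)amino, so they bear on the change only loosely. Compound 3 (24.5 uM) has no measured neighbour with a clearly lower number, and compound 1 shows that a higher number is possible in this assay here. A modest rise is therefore expected, of about the size of the measured steps. The expected step is a 2.0-fold higher number from compound 3 to compound 4 (0.31 log units; beyond the scatter) and remains an estimate. Compound 4 is estimated at 50 uM with an expected range from 18 uM to 100 uM in this series.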

Compound 4, half-maximal toxic concentration: > 100 uM
Compound 4: no number, only a limit (the forecaster's own chance of this, stated with the estimate: 25%); middle value at least 2.0-fold (0.30 log units) away from the limit.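

In this assay compound 4 gives > 100 uM, which is a limit of the assay and not a number, so a group of 5 heavy atoms carrying a hydrogen-bond acceptor can sit on this aromatic carbon, ortho to a fused ring, without the number falling to the level of the bromo and methoxy compounds. Within the data shown here, the exchange of bromo gives an at least 4.0-fold higher number from compound 3 to compound 4 (0.61 log units; beyond the scatter), and the exchange of methoxy gives an at least 2.2-fold higher number from compound 2 to compound 4 (0.35 log units; beyond the scatter), so methyl is no longer the only group that reaches the limit, and the exact numbers of compound 2 and compound 3 do not set the range for this position. The step between compound 1 and compound 4 cannot be read, and the two readable steps fix only a minimum size: the limit of > 100 uM in this assay, at which 2 of the 4 values shown sit.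

Open, from the compounds shown here alone, is whether a plain amine or a carboxylic acid on this aromatic carbon would also reach the limit, or would give an exact number as bromo and methoxy do. Also open, going by these compounds, is whether acetylamino, without the methyl on nitrogen, would behave as acetyl(methyl)amino does, and how methyl and acetyl(methyl)amino rank against each other.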